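Swapping the formyl-furan for a pyrazole on a pyridine core

This account rests on a few compounds, and the source may have more. Where it says the series, first, only, none or still open, it means among the compounds named here.

Of the compounds shown here, three sharing one core have been measured in a functional assay on MV4-11 cells (Homo sapiens) for inhibition, read by resazurin assay, with a stated time of 72 h; on this read-out higher numbers stand for weaker inhibition of growth and lower numbers for stronger inhibition of growth. Compound 1 `O=C1NCCC12CCN(c1c(Cl)cncc1-c1ccoc1)CC2` gives 750 nM, compound 2 `O=Cc1ccc(-c2cncc(Cl)c2N2CCC3(CCNC3=O)CC2)o1` gives 5190 nM, and compound 3 `Cc1ccc(-c2cncc(Cl)c2N2CCC3(CCNC3=O)CC2)s1` gives 650 nM. Compound 2 shows the highest number of the three, and both of its neighbours lie beyond the scatter: the step of a 6.9-fold higher number from compound 1 to compound 2 (0.84 log units; beyond the scatter) and the step of an 8.0-fold lower number from compound 2 to compound 3 (0.90 log units; beyond the scatter). Compounds 1 and 3 sit within the scatter of each other, as a 1.2-fold lower number from compound 1 to compound 3 (0.06 log units; within the scatter) shows.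

Compound 4 `O=C1NCCC12CCN(c1c(Cl)cncc1-c1cn[nH]c1)CC2` has not yet been measured. It differs from compound 2 in one place: 1H-pyrazol-4-yl in place of 5-formylfuran-2-yl on an aromatic carbon. The two measured steps that bear on this change both replace 5-formylfuran-2-yl with another five-membered aromatic ring, and both lower the number by a modest amount. A step of similar size, in the same direction, is therefore expected here, placing compound 4 near compounds 1 and 3.

In this assay compound 4 is estimated at 800 nM, with a range from 300 nM to 2500 nM; this estimate means the step of a 6.5-fold lower number from compound 2 to compound 4 (0.81 log units; beyond the scatter).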

Compound 4, concentration for 50% growth inhibition: 8520 nM
For compound 4 the middle estimate is 11-fold (1.03 log units) below the measured one, and the stated range ends below it.
By their numbers in this assay, from the lowest: compounds 3 and 1 (each within the scatter of the next); then compounds 2 and 4 (each within the scatter of the next).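

In this assay, the pyrazole does not fall in with the two other rings that lack a formyl group: it sits well apart from both furan-3-yl (an 11-fold higher number from compound 1 to compound 4 (1.06 log units; beyond the scatter)) and 5-methylthiophen-2-yl (a 13-fold higher number from compound 3 to compound 4 (1.12 log units; beyond the scatter)), and both steps are large. Compound 4 cannot be told apart from the formyl-bearing compound 2 (a 1.6-fold higher number from compound 2 to compound 4 (0.22 log units; within the scatter)), so removing the 5-formylfuran-2-yl group does not by itself give the lower number. At this position, ortho to a large group, having a five-membered aromatic ring is therefore not enough to stay level with compound 1 and compound 3, and which ring is attached matters.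

No measurement on hand accounts for this gap. On these data alone, whether a thiazole ring, or a pyrazole carrying an ethyl group on its nitrogen, would group with compound 1 or with compound 4 remains open.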